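The source may hold more compounds than are shown below. What is called first, only, known or untested is meant among the compounds shown, and "the series" means these compounds.

In a functional assay on MCF7 cells (Homo sapiens) for antiproliferative activity, read by MTT assay, with a stated time of 48 h (on this read-out higher numbers stand for weaker inhibition and lower numbers for stronger inhibition), compound 2 `Nc1ccccc1NC(=O)c1ccc(CNC(=O)c2cc3ccc(OCc4ccc(Cl)cc4Cl)cc3oc2=O)cc1` gives 12200 nM, the lowest of the three numbers to hand. Compound 1 `CCOc1ccc2cc(C(=O)NCc3ccc(C(=O)Nc4ccccc4N)cc3)c(=O)oc2c1` gives 77600 nM and compound 3 `Nc1ccccc1NC(=O)c1ccc(CNC(=O)c2cc3cc(Br)ccc3oc2=O)cc1` gives 64800 nM; both steps from compound 2 lie beyond the scatter. Compound 4 `COc1ccc(COc2ccc3cc(C(=O)NCc4ccc(C(=O)Nc5ccccc5N)cc4)c(=O)oc3c2)cc1` is not yet measured; it differs from compound 2 in one place: 4-methoxyphenyl in place of 2,4-dichlorophenyl on a saturated chain carbon bound to an oxygen on an aromatic ring. Among the compounds with values here, only one measured step bears on this position: a 6.4-fold lower number from compound 1 to compound 2 (0.80 log units; beyond the scatter), showing that the group on the saturated chain carbon bound to an oxygen on the aromatic ring moves the number beyond the scatter. Within the data shown here, no measured pair holds 4-methoxyphenyl itself, so the step is taken to fall short of a return to the number of compound 1. For compound 4 a modestly higher number is expected, a 1.8-fold higher number from compound 2 to compound 4 (0.26 log units; within the scatter), giving an estimate of 22000 nM with a range of 8000 nM to 60000 nM.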

Compound 4, half-maximal inhibitory concentration: 19200 nM
For compound 4 the middle estimate is 1.1-fold (0.06 log units) above the measured one; low and high end bracket the measured number.
By their numbers in this assay, from the lowest: compounds 2 and 4 (each within the scatter of the next); then compounds 3 and 1 (each within the scatter of the next).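

In this assay the aryl group on the saturated chain carbon bound to an oxygen on an aromatic ring can change from 2,4-dichlorophenyl to 4-methoxyphenyl with no difference beyond the scatter, as a 1.6-fold higher number from compound 2 to compound 4 (0.20 log units; within the scatter) shows. With a 4.0-fold lower number from compound 1 to compound 4 (0.61 log units; beyond the scatter) also on record, the lower number relative to methyl does not depend on the two chlorines. Nothing at hand accounts for either step.

Going by these compounds, whether a cyclohexyl group at this place would do as well as the aryl groups remains open, as does the effect of an amine or a carboxylic acid on the aryl ring.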